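Adding one methyl to compound 2

This account rests on a few compounds, and the source may have more. Where it says the series, first, only, none or still open, it means among the compounds named here.

In a functional assay on HeLa cells (Homo sapiens) for antiproliferative activity, read by sulforhodamine B assay, with a stated time of 48 h (on this read-out lower numbers stand for stronger inhibition and higher numbers for weaker inhibition), compound 1 (`COc1ccc2nc(-c3ccc(N/C=C\C(=O)c4ccc(OC)c([N+](=O)[O-])c4)c(C)c3)sc2c1`) gives 17600 nM and compound 2 (`COc1ccc2nc(-c3ccc(N/C=C\C(=O)c4cc(OC)c(OC)c([N+](=O)[O-])c4)cc3)sc2c1`) gives 16100 nM as its value, and these two numbers lie within the usual scatter of each other. Within the data shown here, compound 2 therefore stands level with the only other measured compound.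

Compound 3 (`COc1ccc2nc(-c3ccc(N/C=C\C(=O)c4cc(OC)c(OC)c([N+](=O)[O-])c4)c(C)c3)sc2c1`) is compound 2 with methyl in place of hydrogen on an aromatic carbon, ortho to a large group (methyl in place of hydrogen on an aromatic carbon). Among the measured compounds shown here, no measured pair shows this change alone, so the data give no direct size for it. Compound 1, which also has this methyl but differs elsewhere, gives 17600 nM in the same range as compound 2, so no step beyond the scatter is expected in this assay for this change. The estimated step (a 1.1-fold lower number from compound 2 to compound 3 (0.03 log units; within the scatter)) stays within the scatter. For compound 3 the expected value is 15000 nM with a range from 6000 nM to 35000 nM in this estimate.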

Compound 3, half-maximal inhibitory concentration: 12100 nM
Estimate against measurement, compound 3: 1.2-fold (0.09 log units) above, within the range that was stated.
By their numbers in this assay, from the lowest: compounds 3, 2 and 1 (each within the scatter of the next).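

The methyl ortho to a large group and meta to a 6-methoxy-1,3-benzothiazol-2-yl group now has a direct size in this assay: a 1.3-fold lower number from compound 2 to compound 3 (0.12 log units; within the scatter), which lies within the usual scatter, so compound 2 and compound 3 read as level. With that methyl present on both compounds, the added methoxy can also be sized, at a 1.5-fold lower number from compound 1 to compound 3 (0.16 log units; within the scatter), and this step too stays within the scatter. Nothing measured here accounts for either step.

The compounds shown hold only hydrogen and methyl at this position, so an ethyl chain, a chlorine atom or an amine there remains an open question. Going by these compounds, all three values also sit close together, so it is unknown whether either step would hold on a more potent compound.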